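Chloro to Fluoro on the Aryl Ether of a Shared Core

This account rests on a few compounds, and the source may have more. Where it says the series, first, only, none or still open, it means among the compounds named here.

compound 1, `Cc1cc(COc2ccc(Cl)cc2)nc(-c2ccccn2)n1`: 251 nM
compound 2, `COc1ccccc1OCc1cc(C)nc(-c2ccccn2)n1`: 2000 nM
compound 3, `COc1cccc(OCc2cc(C)nc(-c3ccccn3)n2)c1`: 2000 nM

Of the compounds shown here, three have been measured in a functional assay on cells for antagonist activity at Free fatty acid receptor 1 (Homo sapiens), read by TR-FRET and inositol phosphate accumulation, with a stated time of 2 h; a lower number here means a stronger inhibitor, a higher number a weaker inhibitor. Compound 1 gives 251 nM, the lowest of the three numbers. Compound 2 gives 2000 nM and compound 3 gives 2000 nM, each a higher number than compound 1 by a gap beyond the scatter, so compound 1 stands as the strongest inhibitor of the set. Compounds 2 and 3 lie within the scatter of each other; no order is claimed between them.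

The next compound to be tested is compound 4, `Cc1cc(COc2ccc(F)cc2)nc(-c2ccccn2)n1`. It differs from compound 1 in one place: fluoro in place of chloro on an aromatic carbon of a six-membered aromatic ring of carbon only. Among the measured compounds shown here, no measured pair shows this exact change, so the size of the step cannot be read from the data. The expectation is a modest loss in this assay for compound 4, a step of a 2.4-fold higher number from compound 1 to compound 4 (0.38 log units; beyond the scatter), still leaving it well below the numbers of compounds 2 and 3. Compound 4 is therefore estimated at 600 nM, with a likely range from 200 nM to 2000 nM.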

Compound 4, half-maximal inhibitory concentration: 631 nM
For compound 4 the middle estimate is 1.1-fold (0.02 log units) below the measured one; low and high end bracket the measured number.
By their numbers in this assay, from the lowest: compound 1; then compound 4; then compounds 2 and 3 (each within the scatter of the next).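

Going from 4-chlorophenyl to 4-fluorophenyl in this assay gives a 2.5-fold higher number from compound 1 to compound 4 (0.40 log units; beyond the scatter), the first step in the set that can be read at a single place with the rest of the molecule held fixed. It shows that this aromatic carbon, para to a large group, is sensitive to which halogen it carries: the exchange of one single-atom substituent for another moves the number by a modest but real amount, with chloro the stronger of the two and fluoro still leaving compound 4 at 631 nM. The compounds shown offer no measurement that explains why chloro and fluoro differ here.

With only these two halogens at this place, the compounds shown leave open whether the trend would continue to bromo, or whether a methyl, a trifluoromethyl or a nitrile would match chloro. They also leave open how an unsubstituted phenyl, or a more different group such as an amine or a carboxylic acid, would behave at this position on the shared core.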